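From (methylsulfonyl)oxy to (4-aminophenyl)amino on the shared core

This account rests on a few compounds, and the source may have more. Where it says the series, first, only, none or still open, it means among the compounds named here.

Compound 1 (`CS(=O)(=O)Oc1c(C(=O)NCc2ccc(F)cc2)nc(Br)c2cccnc12`) offers no starting number: in a functional assay on MCF7 cells (Homo sapiens) for cytotoxicity, read by MTT assay, with a stated time of 72 h (on this read-out higher numbers stand for weaker inhibition and lower numbers for stronger inhibition), compound 1 is recorded as ("not determined" (no result reported)). Within the data shown here, the only number nearby is from compound 2 (`N[C@H]1CC[C@H](Nc2c(C(=O)NCc3ccc(Oc4ccccc4)cc3)nc(Br)c3cccnc23)CC1`), which gives 7900 nM in this assay and carries a different amide side chain. Compound 3 (`Nc1ccc(Nc2c(C(=O)NCc3ccc(F)cc3)nc(Br)c3cccnc23)cc1`) follows from compound 1 by one change ((4-aminophenyl)amino in place of (methylsulfonyl)oxy on an aromatic carbon), with (4-aminophenyl)amino in place of (methylsulfonyl)oxy on an aromatic carbon. No measured step sizes this change, so no direction is claimed from compound 1, and compound 3 is expected within the scatter of compound 2 in this assay. Compound 3 is estimated at 5000 nM (expected range 1200 nM to 20000 nM).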

Compound 3, half-maximal inhibitory concentration: 4000 nM
Beside the measured number, compound 3's estimate is 1.3-fold (0.10 log units) above it; the measured number falls inside the stated range.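

Among these compounds, with compound 1 at "not determined" (no result reported) in this assay no step to compound 3 can be read. No evidence on hand bears on this result.

The compounds shown leave open what (4-aminophenyl)amino in place of (methylsulfonyl)oxy does to cytotoxicity on the shared core.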